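Replacing 2-methoxyethyl with benzyloxycarbonyl on the shared core

The source may report more compounds than this note shows. Statements on the series, on what has been measured and on what is new or still open speak of the compounds shown alone.

Compound 1 `C#CCn1c2ccc([N+](=O)[O-])cc2c(=O)n1Cc1ccccc1`: 195000 nM
Compound 2 `COCCn1c2ccc([N+](=O)[O-])cc2c(=O)n1Cc1ccccc1`: > 256000 nM (a limit)

Both compounds were tested in an ADME assay on L929 cells (Mus musculus) for cytotoxicity, read by resazurin assay, with a stated time of 48 h; on this read-out higher numbers stand for lower toxicity in this test and lower numbers for higher toxicity in this test. Compound 2 gives > 256000 nM, which is a limit of the assay and not a number. Compound 3 `O=C(OCc1ccccc1)n1c2ccc([N+](=O)[O-])cc2c(=O)n1Cc1ccccc1` carries benzyloxycarbonyl in place of 2-methoxyethyl on an aromatic nitrogen. Within the data shown here, the one measured step, an at least 1.3-fold higher number from compound 1 to compound 2 (0.11 log units; that floor lies within the scatter), exchanges other groups and gives little guidance here. Among the measured compounds shown here, the only actual number, that of compound 1 at 195000 nM, suggests a modest move toward a lower number in this assay. The expected change is an at least 1.6-fold lower number from compound 2 to compound 3 (0.20 log units; that floor lies within the scatter). For compound 3 the estimated value is 160000 nM, with an expected range of 60000 nM to 256000 nM.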

Compound 3, concentration lethal to 50% of the cells: 86100 nM
Compound 3: middle estimate off by 1.9-fold (0.27 log units), on the high side; the measured number falls inside the stated range.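

With benzyloxycarbonyl on this aromatic nitrogen, this assay shows changes beyond the scatter: an at least 2.9-fold lower number from compound 2 to compound 3 (0.47 log units; beyond the scatter), and a 2.3-fold lower number from compound 1 to compound 3 (0.36 log units; beyond the scatter). The earlier exchange of propargyl for 2-methoxyethyl had shown only a floor within the scatter, so this position can respond to the group placed on it. Compound 2 stands only as a limit, not a number: the limit of > 256000 nM in this assay, at which 1 of the 3 values shown sits.

The compounds shown do not separate the part played by the carbonyl from that of the aromatic ring within benzyloxycarbonyl. From the compounds shown here alone, how an amine or a longer ether chain on this nitrogen would read also remains open.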